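Phenyl for methyl on an acetyl ester, at the limit

A few compounds are considered here, and "the series" means these few. Any claim that something is new, unique, unknown or untested is made for them only; others in the source may bear on it.

Of the compounds shown here, three have been measured, all built on a shared core: compound 1 `CC(=O)O[C@@H]1OC(=O)[C@@](C(C)=O)(C2SCCCS2)[C@@H]1C`, compound 2 `CC(=O)O[C@@H]1OC(=O)[C@](O)(C(C)=O)[C@@H]1C` and compound 3 `CC(=O)O[C@@H]1OC(=O)[C@](OC(C)=O)(C(C)=O)[C@@H]1C`. In a functional assay on DA-3 cells for cytotoxicity against DA-3 cell line (Mus musculus), read by MTT assay (a higher number here means a weaker inhibitor, a lower number a stronger inhibitor), compound 1 gives > 50000 nM, which is a limit of the assay rather than a number. Compound 2 gives > 50000 nM in this assay, again a limit. Compound 3 gives > 50000 nM in this assay, once more a limit. Compound 3 therefore stands exactly where the other two stand, since the limit of > 50000 nM in this assay, at which 3 of the 3 values shown sit, holds every value shown. For that reason the three steps between measured compounds are unreadable: a step that the two limits leave unreadable from compound 1 to compound 2, a step that the two limits leave unreadable from compound 1 to compound 3 and a step that the two limits leave unreadable from compound 2 to compound 3 each run from one limit to another, so their size cannot be told.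

Compound 4 `CC(=O)O[C@@H]1OC(=O)[C@](OC(=O)c2ccccc2)(C(C)=O)[C@@H]1C` differs from compound 3 by phenyl in place of methyl on a carbonyl carbon. Among the compounds with values here, none of the measured steps touches a carbonyl carbon, so no step bears directly on this change, and nothing measured shows a direction. With every value sitting at the limit, the expectation is that compound 4 stays there too, and the step from compound 3 is expected to be a number no higher from compound 3 to compound 4 (the limit leaves the size open). Compound 4 is estimated to give 50000 nM in this assay, within a range from 15000 nM to 150000 nM.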

Compound 4, half-maximal inhibitory concentration: 3000 nM
For compound 4 the middle estimate is 17-fold (1.22 log units) above the measured one; measured number outside the range, below it.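

Swapping methyl for phenyl on this carbonyl carbon gives, in this assay, an at least 16-fold lower number from compound 3 to compound 4 (1.22 log units; beyond the scatter), and this is the first change in the set whose effect can be read. The earlier steps shown here all run from one limit to another and cannot be read, whereas this one shows that the group on this carbonyl carbon can matter a great deal for the read-out. Compound 4 is also the only compound shown that gives a number rather than a limit: the limit of > 50000 nM in this assay, at which 3 of the 4 values shown sit.

The compounds shown do not tell whether the aromatic ring itself is what counts, or whether another group on this carbonyl carbon, such as a cyclohexyl ring or a longer chain like butyl, would lower the number in the same way. They also leave open whether a methoxy group or an amine on the phenyl ring would move the number further, and whether the same change would hold on any cell line other than the one tested here.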